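Methyl in Place of Hydrogen on the Anilide of Compound 3

This account rests on a few compounds, and the source may have more. Where it says the series, first, only, none or still open, it means among the compounds named here.

Compound 1 `COc1ccc(NC(=O)c2nc(N)nc3ccccc23)cc1`: 87.5 nM
Compound 2 `Nc1nc(C(=O)Nc2ccc(Br)cc2)c2ccccc2n1`: 550 nM
Compound 3 `O=C(Nc1ccccc1)c1nc(=O)[nH]c2ccccc12`: 50 nM

In an assay on CHO cells for displacement of a labelled ligand from adenosine receptor A3 (Homo sapiens) (a lower number here means a stronger inhibitor, a higher number a weaker inhibitor), compound 3 gives the lowest number of the three measured compounds. Compound 1 sits nearest to it, within the scatter, while compound 2 lies furthest away, beyond the scatter. Compound 4 `Cc1ccc(NC(=O)c2nc(=O)[nH]c3ccccc23)cc1` differs from compound 3 by methyl in place of hydrogen on an aromatic carbon. For the measured compounds named here, no measured step involves this change. Going by the values given here, the only measured step, a 6.3-fold higher number from compound 1 to compound 2 (0.80 log units; beyond the scatter), concerns a different exchange on the core shared by compounds 1 and 2, not the core of compound 3, and so gives no direct guidance. With nothing pointing to a shift, the expected step is no change at the digits printed from compound 3 to compound 4 (within the scatter), within the scatter. The estimate for compound 4 in this assay is 50 nM, with a range from 20 nM to 150 nM.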

Compound 4, inhibition constant: 26.7 nM
The estimate for compound 4 lay 1.9-fold (0.27 log units) above the measured number; low and high end bracket the measured number.
By their numbers in this assay, from the lowest: compounds 4, 3 and 1 (each within the scatter of the next, the first and the last beyond it); then compound 2.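

Methyl in place of hydrogen, on an aromatic carbon para to a large group of the anilide, leaves compound 4 within the scatter of compound 3 in this assay (a 1.9-fold lower number from compound 3 to compound 4 (0.27 log units; within the scatter)). The position therefore accepts this one added carbon on the core of compound 3 without a change that can be told from the scatter. Nothing measured here accounts for the result. On these data alone, whether an amine, a carboxylic acid or a longer chain would be accepted at this position stays open, as does whether methyl behaves the same way on the core of compound 1.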